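A few compounds are considered here, and "the series" means these few. Any claim that something is new, unique, unknown or untested is made for them only; others in the source may bear on it.

Compound 1 `COc1ccc([C@H]2CC(=O)N(Cc3cccc(N)c3)C2)cc1OC1CCCC1`: > 10000 nM
Compound 2 `COc1ccc([C@H]2CC(=O)N(C(C)=O)C2)cc1OC1CCCC1`: > 10000 nM

In a functional assay on HEK293 cells (Homo sapiens) for cytotoxicity (a higher number here means that more compound is tolerated, a lower number that less compound is tolerated), compound 1 gives only a limit of the assay, > 10000 nM. In the same assay compound 2 likewise gives only a limit, > 10000 nM. For the measured compounds named here, the single measured step, a step that the two limits leave unreadable from compound 1 to compound 2, cannot be read, since both of its ends rest at the limit of > 10000 nM in this assay, at which 2 of the 2 values shown sit. Compound 3 `COc1ccc([C@H]2CC(=O)N(c3cccc(C(F)(F)F)c3)C2)cc1OC1CCCC1` differs from compound 2 by 3-(trifluoromethyl)phenyl in place of acetyl on an amide-type nitrogen in a ring. Going by the values given here, no measured step bears on this change, so nothing beyond the scatter is expected in this assay. Compound 3 is expected near 15000 nM, between 4000 nM and 50000 nM, an expected step that the limit leaves unreadable from compound 2 to compound 3 that most likely ends again at the limit.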

Compound 3, half-maximal cytotoxic concentration: > 10000 nM
Compound 3: only a limit was reported; the forecaster's own chance of this, stated with the estimate: 65%; the middle value lies beyond the limit too.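

In this assay compound 3 gives only a limit, > 10000 nM, so its steps from compound 1 and from compound 2 cannot be read. The compounds shown leave open whether the groups on the amide-type nitrogen in a ring differ at all in tolerated concentration, since the values offer no number to compare: the limit of > 10000 nM in this assay, at which 3 of the 3 values shown sit.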